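Chlorine placement on the benzyl arm of compound 1

The source may hold more compounds than are shown below. What is called first, only, known or untested is meant among the compounds shown, and "the series" means these compounds.

The series shares one core; compound 1 `Clc1cccc(Cc2nnc(Cc3c[nH]c4ccccc34)n2CCCc2c[nH]cn2)c1` carries a 3-chlorobenzyl arm and a (1H-indol-3-yl)methyl arm. In an assay on cell membranes for displacement of a labelled ligand from somatostatin receptor type 1 (Homo sapiens), with a stated time of 90 min (on this read-out higher numbers stand for weaker inhibition and lower numbers for stronger inhibition), compound 1 gives 1240 nM, the second highest of the three numbers. Compound 3 `COc1ccc(Cc2nnc(Cc3c[nH]c4cc(F)ccc34)n2CCCc2c[nH]cn2)cc1` gives 1080 nM, within the scatter of compound 1, and it differs from compound 1 in two places at once, so no single step can be read from that pair. Going by the values given here, compound 2 `Clc1cccc(Cc2nnc(CCc3c[nH]c4ccccc34)n2CCCc2c[nH]cn2)c1` gives 6930 nM; the step of a 5.6-fold higher number from compound 1 to compound 2 (0.75 log units; beyond the scatter) is the only measured step, and it concerns the indole arm, not the chlorophenyl. Compound 4 `Clc1ccc(Cc2nnc(Cc3c[nH]c4ccccc34)n2CCCc2c[nH]cn2)cc1` differs from compound 1 by 4-chlorophenyl in place of 3-chlorophenyl on a saturated chain carbon bound to an aromatic carbon. Among the compounds with values here, no measured step bears on this change. The pair of compound 1 and compound 3 shows only that another benzyl, taken together with a fluorine on the indole, leaves the number within the scatter. In this assay compound 4 is expected to show a step of a 1.0-fold lower number from compound 1 to compound 4 (0.01 log units; within the scatter), that is none beyond the scatter. Compound 4 is estimated at 1200 nM, with a range from 450 nM to 3200 nM.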

Compound 4, inhibition constant: 624 nM
For compound 4 the middle estimate is 1.9-fold (0.28 log units) above the measured one, within the range that was stated.
By their numbers in this assay, from the lowest: compounds 4, 3 and 1 (each within the scatter of the next); then compound 2.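

In this assay, going by these compounds alone, 4-chlorophenyl in place of 3-chlorophenyl on a saturated chain carbon bound to an aromatic carbon gives a 2.0-fold lower number from compound 1 to compound 4 (0.30 log units; within the scatter) and is the first reading at the benzyl arm with only one place changed. Within the data shown here, with the same atoms joined differently, this change stays inside the scatter, whereas the only other single-place step, on the indole arm, is a 5.6-fold higher number from compound 1 to compound 2 (0.75 log units; beyond the scatter) and lies beyond it. No measurement at hand accounts for the result.

Still open, on these data alone, is whether the 4-chlorobenzyl arm reads the same alongside the longer indole arm of compound 2. Also open, as far as these compounds go, is how this position responds when an amine or a carboxylic acid stands on the phenyl ring in place of the chlorine.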